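Adding one methoxy to compound 2

The source may report more compounds than this note shows. Statements on the series, on what has been measured and on what is new or still open speak of the compounds shown alone.

In a functional assay on SK-OV-3 cells (Homo sapiens) for cytotoxicity, read by spectrophotometry, with a stated time of 72 h (on this read-out lower numbers stand for stronger inhibition and higher numbers for weaker inhibition), compound 1 (`COc1cc(-c2cccc(=O)n2-c2cc(OC)c(OC)c(OC)c2)cc(OC)c1OC`) reads 844 nM and compound 2 (`COc1ccc(-n2c(-c3cc(OC)c(OC)c(OC)c3)cccc2=O)cc1`) reads 1540 nM so compound 2 sits within the scatter of compound 1. Compound 3 (`COc1ccc(-n2c(-c3cc(OC)c(OC)c(OC)c3)cccc2=O)cc1OC`) follows from compound 2 by methoxy in place of hydrogen on an aromatic carbon with methoxy in place of hydrogen on an aromatic carbon, ortho to a methoxy group. Among the compounds with values here, no measured step guides this change. From compound 2 at 1540 nM nothing beyond the scatter is expected in this assay for this addition. An estimated 1.4-fold lower number from compound 2 to compound 3 (0.15 log units; within the scatter) would stay within the scatter. For compound 3 the estimate is 1100 nM with an expected range from 400 nM to 3000 nM in this assay series.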

Compound 3, half-maximal inhibitory concentration: 14300 nM
Beside the measured number, compound 3's estimate is 13-fold (1.11 log units) below it; the measured number lies above the stated range.
By their numbers in this assay, from the lowest: compounds 1 and 2 (each within the scatter of the next); then compound 3.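

In this assay this position is not neutral: methoxy in place of hydrogen on an aromatic carbon, ortho to a methoxy group, gives a 9.3-fold higher number from compound 2 to compound 3 (0.97 log units; beyond the scatter). Hydrogen in place of methoxy on an aromatic carbon gives a 17-fold higher number from compound 1 to compound 3 (1.23 log units; beyond the scatter), so the read-out does not simply follow the number of methoxy groups on this ring, and compound 3 stands above both other compounds. Nothing at hand accounts for this.

From the compounds shown here alone, whether the rise belongs to methoxy itself or to any group at this place stays open. A hydroxy, a fluorine or an amine there would separate the two.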